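A few compounds are considered here, and "the series" means these few. Any claim that something is new, unique, unknown or untested is made for them only; others in the source may bear on it.

Compound 1 `NS(=O)(=O)Oc1ccc2c(c1)CN(C(=O)c1ccc(N3CCCCC3)cc1)CC2` gives 1.93 in a physicochemical assay for lipophilicity; on this read-out lower numbers stand for lower lipophilicity and higher numbers for higher lipophilicity. Compound 2 `CCN(Cc1ccccn1)c1ccc(C(=O)N2CCc3ccc(OS(N)(=O)=O)cc3C2)cc1` gives 1.93 in this assay, and compound 3 `CN(C)CCCN(Cc1ccccc1)c1ccc(C(=O)N2CCc3ccc(OS(N)(=O)=O)cc3C2)cc1` gives 1.93. Compound 2 therefore stands level with both at the digits shown; the one measured step, no change at the digits printed from compound 1 to compound 2 (within the scatter), lies within the scatter, and the values of compound 2 and compound 3 show no difference either.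

Compound 4 `CCCN(CCC)c1ccc(C(=O)N2CCc3ccc(OS(N)(=O)=O)cc3C2)cc1` differs from compound 2 by dipropylamino in place of ethyl((pyridin-2-yl)methyl)amino on an aromatic carbon. For the measured compounds named here, no measured step trades a ring-bearing amino group for a chain-only one, so the bearing of the data is indirect: the step from compound 1 to compound 2 changed the amino substituent on the same aromatic carbon without moving this assay, and compound 3 carries yet another amino group at the same value. A step of at most modest size is therefore expected for compound 4, a number 0.27 log units higher from compound 2 to compound 4 (within the scatter), tending slightly upward if anything. Compound 4 is estimated at 2.2, within 1.7 to 2.8.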

Compound 4, partition coefficient: 3.07
For compound 4 the middle estimate is 0.87 log units below the measured one; the measured number lies above the stated range.
By their numbers in this assay, from the lowest: compounds 1, 2 and 3 (each within the scatter of the next); then compound 4.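

With dipropylamino in place of ethyl((pyridin-2-yl)methyl)amino on this aromatic carbon, para to a large group, this assay shows a number 1.14 log units higher from compound 2 to compound 4 (beyond the scatter), and with dipropylamino in place of piperidin-1-yl it shows a number 1.14 log units higher from compound 1 to compound 4 (beyond the scatter). The level values of compound 1, compound 2 and compound 3 therefore do not mean that the read-out is insensitive to every amino group at this position, and among the compounds shown, only compound 4 carries an amino group with no ring and stands apart. No measurement shown accounts for the size of these steps.

The compounds shown leave open whether the steps follow the two propyl chains themselves or the absence of a ring. They also leave open where diethylamino, dibutylamino or morpholin-4-yl would fall in this assay.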